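The compounds below may be only part of what the source reports. "The series", "measured", "known", "first", "only" and "open" are said of these compounds alone.

In a physicochemical assay for acid dissociation, compound 1 (`Nc1nc(-n2cc(C(=O)O)c(=O)c3cc(F)c([C@H]4C[C@H](O)C4)c(Cl)c32)c(F)cc1F`) gives 5.04 and compound 2 (`Nc1nc(-n2cc(C(=O)O)c(=O)c3cc(F)c([C@H]4C[C@@H](O)C4)c(Cl)c32)c(F)cc1F`) gives 4.96 so the two stand level within the scatter. Compound 3 (`Nc1nc(-n2cc(C(=O)O)c(=O)c3cc(F)c(N4CC(N)C4)c(Cl)c32)c(F)cc1F`) differs from compound 2 by one change (3-aminoazetidin-1-yl in place of 3-hydroxycyclobutyl on an aromatic carbon): 3-aminoazetidin-1-yl in place of 3-hydroxycyclobutyl on an aromatic carbon. Within the data shown here, the only measured step (a number 0.08 log units lower from compound 1 to compound 2 (within the scatter)) joins mirror images (the fact that compounds 1 and 2 differ only in the configuration as drawn) and so gives no size for a change of group. In this assay the expected step (a number 0.54 log units higher from compound 2 to compound 3 (beyond the scatter)) is a modest upward one, estimated from the structural change alone. For compound 3 the estimated value is 5.5 (range 4.9 to 6.3).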

Compound 3, acid dissociation constant: 5.33
Compound 3: the middle estimate sits 0.17 log units above what was measured; measured number inside the range.
By their numbers in this assay, from the lowest: compounds 2, 1 and 3 (each within the scatter of the next, the first and the last beyond it).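

In this assay, 3-aminoazetidin-1-yl in place of 3-hydroxycyclobutyl on an aromatic carbon gives a size for a change of group at this position: a number 0.37 log units higher from compound 2 to compound 3 (beyond the scatter), and a number 0.29 log units higher from compound 1 to compound 3 (within the scatter). One change thus reads on both sides of the scatter, and the two readings differ because the starting compounds form a pair in configuration only: the fact that compounds 1 and 2 differ only in the configuration as drawn

On these data alone, whether the step follows the ring nitrogen or the amine of the entering group stays open. 3-Aminocyclobutyl or 3-hydroxyazetidin-1-yl at this position would separate the two.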